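The source may hold more compounds than are shown below. What is called first, only, known or untested is meant among the compounds shown, and "the series" means these compounds.

compound 1 `CC(=O)N[C@@H]1CCC[C@H](C(=O)Nc2cc(-c3cnc(C)n3C(C)C)ccn2)C1`: 660000 nM
compound 2 `CC(=O)N[C@@H]1CCC[C@H](C(=O)Nc2cc(-c3cnn4c3CCCC4)c(Cl)cn2)C1`: 310000 nM
compound 3 `CC(=O)N[C@@H]1CC[C@H](C(=O)Nc2cc(-c3cnn4c3CC(C)(C)C4)c(Cl)cn2)C1`: 35000 nM

In a physicochemical assay for solubility, in phosphate buffer, at pH 7.4 (on this read-out lower numbers stand for lower solubility and higher numbers for higher solubility), compound 3 gives 35000 nM, the lowest of these three numbers. Compound 2 gives 310000 nM and compound 1 gives 660000 nM. Both lie higher than compound 3, beyond the usual scatter of repeated measurements.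

The next compound to be measured, compound 4 `CC1(C)Cc2c(-c3cc(NC(=O)[C@H]4C[C@@H](O)C4)ncc3Cl)cnn2C1`, keeps the core of compound 3 and changes one group. It has 3-hydroxycyclobutyl in place of 3-acetamidocyclopentyl on a carbonyl carbon.

Going by the values given here, no two measured compounds differ in only one place, and none of them carries a 3-hydroxycyclobutyl group, so the data offer no direct precedent for this change. The expectation therefore rests on weak evidence. Compound 3, at 35000 nM, sits at the bottom of this small set, so a new compound seems more likely to land above it than below it. A rise in this assay is expected, but a fall would not be a surprise.

The estimated change is a 2.3-fold higher number from compound 3 to compound 4 (0.36 log units; beyond the scatter).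

The estimated value for compound 4 is 80000 nM.

The expected range for compound 4 runs from 20000 nM to 300000 nM.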

Compound 4, solubility: 15000 nM
The estimate for compound 4 lay 5.3-fold (0.73 log units) above the measured number; measured number below the stated range.
By their numbers in this assay, from the lowest: compound 4; then compound 3; then compound 2; then compound 1.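

Going by these compounds alone, compound 3 and compound 4 are the first pair here that differ in only one place, so the group on the carbonyl carbon can now be judged directly in this assay. Replacing 3-acetamidocyclopentyl with 3-hydroxycyclobutyl gives a 2.3-fold lower number from compound 3 to compound 4 (0.37 log units; beyond the scatter), a modest step, and it makes compound 4 the lowest of the set. The entering group has fewer heavy atoms and a smaller ring, yet it has the same counts of hydrogen-bond donors and acceptors, and this smaller group on the shared core did not raise the number in this single pair. No measurement shown here gives a cause for this step.

The ring and its substituent change together in this one step, so the effect of going from a five-membered to a four-membered ring cannot be separated from that of exchanging acetamido for hydroxy. Going by these compounds, a 3-hydroxycyclopentyl or a 3-aminocyclobutyl group on the same carbonyl carbon would help pull these two changes apart, and how either would behave on this core remains open.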